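Bromophenyl Amide on a Benzyl Core: Expected Cytotoxicity

This account rests on a few compounds, and the source may have more. Where it says the series, first, only, none or still open, it means among the compounds named here.

Four compounds share one core and differ in two places. Compound 1 `O=C(CN1CCN(c2nnc(Cc3ccncc3)c3ccccc23)CC1)Nc1cccc(Br)c1` and compound 2 `O=C(CN1CCN(c2nnc(Cc3ccncc3)c3ccccc23)CC1)Nc1ccc(F)c(Cl)c1` carry the same core; the difference between them is 3-bromophenyl in place of 3-chloro-4-fluorophenyl on an amide-type nitrogen. In a functional assay on A549 cells (Homo sapiens) for cytotoxicity, read by MTT assay, with a stated time of 72 h (on this read-out higher numbers stand for weaker inhibition and lower numbers for stronger inhibition), compound 2 gives 12300 nM, while compound 1 gives 1530 nM, so the step is an 8.0-fold lower number from compound 2 to compound 1 (0.91 log units; beyond the scatter). Compound 3 `O=C(CN1CCN(c2nnc(Cc3ccccc3)c3ccccc23)CC1)Nc1ccc(F)c(Cl)c1` differs from compound 2 only in its core, by phenyl in place of pyridin-4-yl on a saturated chain carbon bound to an aromatic carbon, and in this assay compound 3 is recorded as "not active" (no number reported), with no number given. Compound 4 `O=C(CN1CCN(c2nnc(Cc3ccccc3)c3ccccc23)CC1)Nc1cccc(Br)c1` stands to compound 3 as compound 1 stands to compound 2: the change is 3-bromophenyl in place of 3-chloro-4-fluorophenyl on an amide-type nitrogen, made at the same place, so it is the same change. From the compounds shown here alone, whether it brings a step of similar size on the core of compound 3 is unknown, since the starting point is only a report of inactivity. The expectation is modest: compound 4 is expected to give 20000 nM in this assay, with a wide range from 3000 nM to 100000 nM, and a real chance that only inactivity is reported again.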

Compound 4, half-maximal inhibitory concentration: "not active" (no number reported)
For compound 4 the study gives words and no number; no gap can be computed for the estimate.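

In this assay, among these compounds, compound 3 and compound 4 are both reported only as not active, so no step between them can be read. No evidence at hand bears on this result. The compounds shown leave open whether 3-bromophenyl in place of 3-chloro-4-fluorophenyl changes cytotoxicity at all on the core of compound 3.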